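This account rests on a few compounds, and the source may have more. Where it says the series, first, only, none or still open, it means among the compounds named here.

Of the compounds shown here, three sharing one core have been read in a functional assay on HepG2 cells (Homo sapiens) for antiproliferative activity, read by MTT assay, with a stated time of 48 h; on this read-out higher numbers stand for weaker inhibition and lower numbers for stronger inhibition. Compound 1 `O=C(CN1CCCC1)Nc1ccc2ncnc(Nc3cccc(C(F)(F)F)c3)c2c1`, which carries 3-(trifluoromethyl)phenyl on a nitrogen on an aromatic ring, gives 25200 nM. Compound 3 `O=C(CN1CCCC1)Nc1ccc2ncnc(Nc3ccc(Cl)cc3)c2c1`, with 4-chlorophenyl in that place, gives 18000 nM. These two share the low end of the numbers shown, and a 1.4-fold lower number from compound 1 to compound 3 (0.15 log units; within the scatter) cannot separate them. Compound 2 `O=C(CN1CCCC1)Nc1ccc2ncnc(Nc3cccc(Cl)c3)c2c1`, with 3-chlorophenyl, gives > 100000 nM, which is a limit of the assay and not a number.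

Compound 4 `O=C(CN1CCCC1)Nc1ccc2ncnc(Nc3cccc(Br)c3)c2c1` differs from compound 3 in one place, 3-bromophenyl in place of 4-chlorophenyl on a nitrogen on an aromatic ring: 3-bromophenyl stands in place of 4-chlorophenyl. Among the compounds with values here, no measured step involves bromo, so the evidence is indirect. Within the data shown here, two steps bear on the change. Replacing 3-chlorophenyl with 4-chlorophenyl gives an at least 5.5-fold lower number from compound 2 to compound 3 (0.74 log units; beyond the scatter), so leaving the 4-chlorophenyl group could raise the number. Yet an at least 3.9-fold higher number from compound 1 to compound 2 (0.59 log units; beyond the scatter) shows that the outcome also depends on the group itself, and compound 1 goes against any rule that a 3-substituted phenyl means a very high number. Compounds 1 and 2 therefore bracket the expectation. The expected step is a 2.8-fold higher number from compound 3 to compound 4 (0.44 log units; beyond the scatter), a modest move towards weaker inhibition. Compound 4 is estimated at 50000 nM, with an expected range of 18000 nM to 100000 nM.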

Compound 4, half-maximal inhibitory concentration: > 100000 nM
Compound 4 ended at the assay's limit; the forecaster's own chance of this, stated with the estimate: 30%; middle value at least 2.0-fold (0.30 log units) from the limit.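

In this assay, 3-bromophenyl on the nitrogen gives an at least 5.5-fold higher number from compound 3 to compound 4 (0.74 log units; beyond the scatter), and exchanging trifluoromethyl for bromo gives an at least 3.9-fold higher number from compound 1 to compound 4 (0.59 log units; beyond the scatter). The very high reading of compound 2 is therefore no longer a lone case, since 3-chlorophenyl and 3-bromophenyl now both reach the top of the range, while compound 1 still goes against any rule that a group in the 3-position alone causes this. Compounds 2 and 4 each stand at a limit and not at a number, so the step between them cannot be read and chloro and bromo cannot be ranked here: the limit of > 100000 nM in this assay, at which 2 of the 4 values shown sit.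

Compound 3 gives 18000 nM. The compounds shown leave open whether the 4-position is what keeps a reading below the limit, a question that 4-bromophenyl or 4-(trifluoromethyl)phenyl on the same nitrogen would test. They also leave open whether 3-methylphenyl, 3-methoxyphenyl or unsubstituted phenyl would fall with compound 1 or at the limit with compounds 2 and 4.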